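Aryl swap on the ring nitrogen: outlook for compound 3

A few compounds are considered here, and "the series" means these few. Any claim that something is new, unique, unknown or untested is made for them only; others in the source may bear on it.

compound 1 `CCCc1nc(-c2ccccc2)c(CNCCCN2CCN(c3cccc(C(F)(F)F)c3)CC2)o1`: 650 nM
compound 2 `CCCc1nc(-c2ccccc2)c(CNCCCN2CCN(c3ccc(C(F)(F)F)cc3)CC2)o1`: 7250 nM

Among the compounds with values here, compound 2 stands at the highest of the two numbers in an assay on HEK293 cells for inhibition of Voltage-dependent T-type calcium channel subunit alpha-1G (Homo sapiens), read by patch clamp; on this read-out lower numbers stand for stronger inhibition and higher numbers for weaker inhibition; the single measured step, an 11-fold higher number from compound 1 to compound 2 (1.05 log units; beyond the scatter), separates it from compound 1, the only neighbour. Within the data shown here, that step replaces 3-(trifluoromethyl)phenyl with 4-(trifluoromethyl)phenyl on the ring amine nitrogen and is the only information on how the aryl group on that nitrogen moves the read-out.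

Compound 3 `CCCc1nc(-c2ccccc2)c(CNCCCN2CCN(c3cccc(C)c3C)CC2)o1` carries 2,3-dimethylphenyl in place of 4-(trifluoromethyl)phenyl on an amine nitrogen in a ring. Among the measured compounds shown here, no measured pair shows a dimethylphenyl group, so the expectation rests on the one step alone: it shows that a change confined to the aryl group on this nitrogen can shift the number by a large amount, and that the 4-(trifluoromethyl)phenyl compound 2 is the weaker end of what has been seen. Leaving that group is therefore expected to give a lower number for compound 3, of the order of a 4.8-fold lower number from compound 2 to compound 3 (0.68 log units; beyond the scatter) in this assay, though with a wide range because only an 11-fold higher number from compound 1 to compound 2 (1.05 log units; beyond the scatter) is available as a guide. The estimate for compound 3 in this assay is 1500 nM, between 350 nM and 6500 nM.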

Compound 3, half-maximal inhibitory concentration: 1780 nM
Beside the measured number, compound 3's estimate is 1.2-fold (0.07 log units) below it, and the stated range covers the measured number.
By their numbers in this assay, from the lowest: compound 1; then compound 3; then compound 2.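

In this assay, the aryl group on the ring amine nitrogen now has a third point: a 4.1-fold lower number from compound 2 to compound 3 (0.61 log units; beyond the scatter), and a 2.7-fold higher number from compound 1 to compound 3 (0.44 log units; beyond the scatter), so the 2,3-dimethylphenyl compound falls inside the span set by the two trifluoromethylphenyl compounds. A trifluoromethyl group is therefore not needed at this position for a number lower than that of compound 2, although among these three compounds the 3-(trifluoromethyl)phenyl of compound 1 still gives the lowest number, with both of its steps beyond the scatter. Nothing available here accounts for these differences between the aryl groups.

The compounds shown do not separate the contributions of the two methyl groups, and they do not show how an unsubstituted phenyl, a chlorophenyl or a methoxyphenyl on the same nitrogen would compare. As far as these compounds go, the shared core and the chain leading to the ring nitrogen are constant across all three compounds, so it remains open whether the order of compound 1, compound 3 and compound 2 would hold with a longer chain.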